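This account rests on a few compounds, and the source may have more. Where it says the series, first, only, none or still open, it means among the compounds named here.

Within the data shown here, compound 3 `COc1cc(N(C)CCN(C)C)c(NC(=O)/C=C\C(C)C)cc1Nc1nc(C)cc(-c2cn(C)c3ccccc23)n1` is one of three compounds measured in a functional assay on A549 cells (Homo sapiens) for antiproliferative activity, read by MTT assay, with a stated time of 72 h; a higher number here means a weaker inhibitor, a lower number a stronger inhibitor. In this assay compound 3 gives 1070 nM, the second highest of the three numbers. Its nearest neighbour is compound 2 `CC/C=C\C(=O)Nc1cc(Nc2nc(C)cc(-c3cn(C)c4ccccc34)n2)c(OC)cc1N(C)CCN(C)C`, which in this assay gives 1090 nM; the furthest is compound 1 `CCC/C=C\C(=O)Nc1cc(Nc2nccc(-c3cn(C)c4ccccc34)n2)c(OC)cc1N(C)CCN(C)C`, which gives 808 nM, and both of those gaps lie within the scatter. Compound 4 `CCC/C=C\C(=O)Nc1cc(Nc2nc(C)cc(-c3cn(C)c4ccccc34)n2)c(OC)cc1N(C)CCN(C)C` has not yet been measured in this assay. The change from compound 3 to compound 4 is propyl in place of isopropyl on a double-bonded chain carbon bound to a double-bonded chain carbon. Among the measured compounds shown here, only one measured step touches the same chain: the change from compound 2 to compound 3, which gave a 1.0-fold lower number from compound 2 to compound 3 (0.01 log units; within the scatter). Compound 1 and compound 2, which differ in two places at once, also return numbers within the scatter of one another. Everything seen so far on this chain is flat, so the step from compound 3 to compound 4 is expected to be a 1.1-fold lower number from compound 3 to compound 4 (0.03 log units; within the scatter). Compound 4 is therefore estimated at 1000 nM, with a range of 500 nM to 2000 nM.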

Compound 4, half-maximal inhibitory concentration: 329 nM
Estimate against measurement, compound 4: 3.0-fold (0.48 log units) above; the whole stated range lies above it.
By their numbers in this assay, from the lowest: compound 4; then compounds 1, 3 and 2 (each within the scatter of the next).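

In this assay the chain is not flat after all: propyl in place of isopropyl on a double-bonded chain carbon gives a 3.3-fold lower number from compound 3 to compound 4 (0.51 log units; beyond the scatter) and is beyond the scatter. From the same starting compound, methyl in place of hydrogen changes little or much according to where it sits: on the saturated chain carbon bound to the double-bonded chain carbon it gives a 1.0-fold lower number from compound 2 to compound 3 (0.01 log units; within the scatter) and stays within the scatter, while two bonds along the chain it gives a 3.3-fold lower number from compound 2 to compound 4 (0.52 log units; beyond the scatter) and lies beyond it. With the propyl chain in place, methyl in place of hydrogen on an aromatic carbon also counts, giving a 2.5-fold lower number from compound 1 to compound 4 (0.39 log units; beyond the scatter) and lying beyond the scatter.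

Nothing available explains these steps. On these data alone, whether a longer chain such as hexyl, or a cyclopropyl group on the same carbon, would lower the number further remains open.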